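From 4-chlorophenyl to phenethyl on the amine chain

The source may report more compounds than this note shows. Statements on the series, on what has been measured and on what is new or still open speak of the compounds shown alone.

Values measured so far in a functional assay on MDA-MB-231 cells (Homo sapiens) for inhibition (on this read-out higher numbers stand for weaker inhibition and lower numbers for stronger inhibition), are these:
compound 1 `O=C(NO)c1ccc(-c2ccc(CNCc3ccc(Cl)cc3)cn2)s1` gives 300 nM
compound 2 `CN(Cc1ccccc1)Cc1ccc(-c2ccc(C(=O)NO)s2)nc1` gives 370 nM

Compound 1 stands level with compound 2, since their two values lie within the usual scatter of each other and neither can be ranked. Compound 3 `O=C(NO)c1ccc(-c2ccc(CNCCCc3ccccc3)cn2)s1` has not yet been measured. It keeps the core of compound 1 and carries phenethyl in place of 4-chlorophenyl on a saturated chain carbon bound to an amine nitrogen. Within the data shown here, no measured pair shows this change, so the data offer no step to lean on. In this assay no shift beyond the scatter is expected, in either direction. The estimated step (no change at the digits printed from compound 1 to compound 3 (within the scatter)) reflects that expectation. For compound 3 the estimated value is 300 nM with an expected range from 100 nM to 900 nM around it.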

Compound 3, half-maximal inhibitory concentration: 250 nM
Estimate against measurement, compound 3: 1.2-fold (0.08 log units) above; the range from low to high includes it.
By their numbers in this assay, from the lowest: compounds 3, 1 and 2 (each within the scatter of the next).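

In this assay, the exchange of 4-chlorophenyl for phenethyl on a saturated chain carbon bound to an amine nitrogen gives a 1.2-fold lower number from compound 1 to compound 3 (0.08 log units; within the scatter), so this position accepts the change without a shift that can be read. The earlier compounds shown here offered no step at this position, and this first one shows that the chlorine can go without any loss beyond the scatter, at least in this pair, where both groups carry a six-membered aromatic ring of carbon only. Nothing on hand explains why the two groups read alike.

Going by these compounds, whether the aromatic ring itself is needed stays open: a carboxylic acid or a simple amine at the end of the chain would test that, and a longer chain would test how far the ring can sit. A single step in one assay gives no trend for this position.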